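A few compounds are considered here, and "the series" means these few. Any claim that something is new, unique, unknown or untested is made for them only; others in the source may bear on it.

Measured compounds:
compound 1, `COC(=O)C1=C(N)Oc2c(OC)cc(Br)cc2C1CC(=O)c1ccc(Cl)cc1`, in a functional assay on MCF7 cells (Homo sapiens) for antiproliferative activity, read by sulforhodamine B assay, with a stated time of 72 h, tested at 30 uM (a lower number here means a stronger effect, a higher number a weaker effect of the compound at the concentration tested), gives 33.8%
compound 2, `COC(=O)C1=C(N)Oc2c(OC)cccc2C1CC(=O)c1ccc(Cl)cc1`, in this assay gives 63.8%
compound 3, `COc1cc(Br)cc2c1OC(N)=C(C#N)C2CC(=O)c1ccc(Cl)cc1`, not yet measured in this assay

Among the measured compounds shown here, compound 1 stands lowest of the two numbers in this assay; the only other number measured is a number 30 percentage points higher from compound 1 to compound 2 (beyond the scatter), where the change is hydrogen in place of bromo on an aromatic carbon. Compound 3 differs from compound 1 by cyano in place of methoxycarbonyl on a double-bonded ring carbon. For the measured compounds named here, no measured step touches this change; the one step known concerns a different place and says nothing about it. The exchange is therefore expected to give no step beyond the scatter, a number 6.2 percentage points higher from compound 1 to compound 3 (within the scatter). Compound 3 is expected to give about 40%, between 15% and 70%.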

Compound 3, a percentage reported as activity, at one concentration (the size of the read-out at that concentration, not a potency): 33.3%
Estimate against measurement, compound 3: 6.7 percentage points above; the range from low to high includes it.
By their numbers in this assay, from the lowest: compounds 3 and 1 (each within the scatter of the next); then compound 2.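

In this assay, among the compounds shown here, cyano in place of methoxycarbonyl on the double-bonded ring carbon gives a number 0.5 percentage points lower from compound 1 to compound 3 (within the scatter), the first reading at this position. With the bromo group kept, the read-out at the tested concentration thus holds across this exchange, so methoxycarbonyl is not required there in this series. No evidence available here accounts for this. Going by these compounds, whether the exchange would hold on the core of compound 2, which lacks the bromo group, remains open, as does the outcome with a carboxylic acid or a primary amide at this place.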